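The compounds below may be only part of what the source reports. "The series", "measured", "known", "first", "only" and "open" are said of these compounds alone.

Three compounds share one core, and compound 3 `CC[C@H](C)[C@H](NC(=O)CN(c1ncnc2c1ncn2C1CCCCO1)C1CC1)C(=O)OCc1ccccc1` stands at the bottom of them. In a functional assay on the whole organism (Tail, strain ICR) with Mus musculus as the target, in the tail flick test, with a stated time of 90 min, at a dose of 25 umol/kg by the oral route (a lower number here means a weaker effect, a higher number a stronger effect of the compound at the dose given), compound 3 gives 22.6%. Compound 2 `NC(=O)CC[C@H](NC(=O)CN(c1ncnc2c1ncn2C1CCCCO1)C1CC1)C(=O)OCc1ccccc1` in this assay gives 37.8%, and compound 1 `CSCC[C@H](NC(=O)CN(c1nc(Cl)nc2[nH]cnc12)C1CC1)C(=O)OCc1ccccc1` in this assay gives 44.6%, so compound 3 lies beyond the scatter below both of them, nearer to compound 2 than to compound 1.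

Compound 4 `O=C(CN(c1ncnc2c1ncn2C1CCCCO1)C1CC1)N[C@@H](CCC(=O)OCc1ccccc1)C(=O)OCc1ccccc1` differs from compound 3 in one place: 2-(benzyloxycarbonyl)ethyl in place of sec-butyl on a saturated chain carbon bound to an amide-type nitrogen and a carbonyl carbon.

For the measured compounds named here, one measured step bears on this change. The step of a number 15.2 percentage points lower from compound 2 to compound 3 (beyond the scatter) replaced a chain carrying a carbonyl group on this same carbon with sec-butyl, and the number fell. The present change runs the other way, taking sec-butyl out and putting in a longer chain that again carries a carbonyl group, though here an ester rather than an amide and with a phenyl ring at its end. On that ground a rise of roughly the size of a number 12.4 percentage points higher from compound 3 to compound 4 (beyond the scatter) is expected for compound 4, bringing it back toward the level of compound 2. Compound 4 is therefore estimated in this assay at 35%, within a range of 20% to 50%.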

Compound 4, a percentage reported as activity, at one dose (the size of the read-out at that dose, not a potency): 25.2%
The estimate for compound 4 lay 9.8 percentage points above the measured number, and the stated range covers the measured number.
By their numbers in this assay, from the lowest: compounds 3 and 4 (each within the scatter of the next); then compounds 2 and 1 (each within the scatter of the next).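

Putting 2-(benzyloxycarbonyl)ethyl in place of sec-butyl gave a number 2.6 percentage points higher from compound 3 to compound 4 (within the scatter) in this assay, so at this saturated chain carbon a carbonyl group in the chain does not by itself raise the number, even with a six-membered aromatic ring added. Benzyloxy in place of amino on a carbonyl carbon gave a number 12.6 percentage points lower from compound 2 to compound 4 (beyond the scatter), which shows that within this chain the group on the carbonyl carbon matters, not the carbonyl alone. Nothing available here explains why the amino end differs from the benzyloxy end.

On these data alone, whether a carboxylic acid or an amine at the end of this chain would reach the level of compound 2 remains open. So does whether a shorter chain ending in the same primary amide would hold that level.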